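Compound 3 at the assay limit, and a phenyl added

The source may report more compounds than this note shows. Statements on the series, on what has been measured and on what is new or still open speak of the compounds shown alone.

In a functional assay on HCCLM7 cells (Homo sapiens) for antiproliferative activity, read by MTT assay, with a stated time of 72 h (a lower number here means a stronger inhibitor, a higher number a weaker inhibitor), compound 1 `Cc1cc(C)nc(Sc2coc3ccccc3c2=O)n1` gives > 50000 nM as a limit of the assay, not a number. Compound 2 `O=c1c(Sc2nc3ccccc3[nH]2)coc2ccccc12` likewise gives > 50000 nM as a limit. Compound 3 `CN1CCN(/C=C2\Oc3ccccc3C2=O)CC1` also gives > 50000 nM as a limit, so no number is known for it. Within the data shown here, the three compounds therefore stand together, as the limit of > 50000 nM in this assay, at which 3 of the 3 values shown sit, records, and they offer no measured step to learn from.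

The next compound, compound 4 `CN1CCN(/C=C2\Oc3ccccc3C2=O)C(c2ccccc2)C1`, carries one structural change from compound 3: phenyl in place of hydrogen on a saturated ring carbon with phenyl in place of hydrogen on a saturated ring carbon. Among the measured compounds shown here, no measured pair shows what such a change does in this assay, so any expectation is loose. For the measured compounds named here, with the limit of > 50000 nM in this assay, at which 3 of the 3 values shown sit, as the only guide, a number could appear only on the stronger side, and another limit is about as likely. The expected change, an at least 1.4-fold lower number from compound 3 to compound 4 (0.15 log units; that floor lies within the scatter), is a modest one towards stronger inhibition. For compound 4 the estimate is 35000 nM, with an expected range from 10000 nM to 80000 nM around it.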

Compound 4, half-maximal inhibitory concentration: > 50000 nM
Compound 4: no number, only a limit; the forecaster's own chance of this, stated with the estimate: 55%; middle value at least 1.4-fold (0.15 log units) from the limit.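

In this assay compound 4 gives > 50000 nM, a limit of the assay and not a number. Compound 3 also stands at a limit, so no step can be read between compound 3 and compound 4. The compounds shown leave open which structural change, if any, would give a measured number in this assay.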